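The source may report more compounds than this note shows. Statements on the series, on what has been measured and on what is new or still open speak of the compounds shown alone.

Measured so far:
- Compound 1 `COc1ccccc1/C=C/C(=O)OC/C=C/c1cc(OC)c(OC)cc1OC`: > 300 mg/kg
- Compound 2 `COc1cc(OC)c(OC)cc1/C=C/COC(=O)/C=C/c1ccc(OC)c(OC)c1`: > 300 mg/kg

In a functional assay on the whole organism (strain Kunming) with Mus musculus as the target, with a stated time of 0.5 h (a lower number here means that less compound is needed, a higher number that more compound is needed for the effect), compound 2 gives > 300 mg/kg, which is a limit of the assay and not a number. Compound 1 gives > 300 mg/kg, also a limit. Together they show (the limit of > 300 mg/kg in this assay, at which 2 of the 2 values shown sit).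

The next compound, compound 3 `COc1cc(OC)c(OC)cc1/C=C/COC(=O)/C=C/c1ccc(Br)cc1`, has not yet been measured. It carries 4-bromophenyl in place of 3,4-dimethoxyphenyl, on a double-bonded chain carbon bound to a double-bonded chain carbon: 4-bromophenyl in place of 3,4-dimethoxyphenyl on a double-bonded chain carbon bound to a double-bonded chain carbon.

Among the compounds with values here, the one measured step at this same place, a step that the two limits leave unreadable from compound 1 to compound 2, has no readable size, so it offers no guide to direction. No clear change is therefore expected in this assay, and a further limit is quite possible. The expected change, an at least 1.0-fold lower number from compound 2 to compound 3 (0.02 log units; that floor lies within the scatter), is only a rough estimate. For compound 3 the expected value is 280 mg/kg, with an estimated range of 110 mg/kg to 600 mg/kg.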

Compound 3, dose for half-maximal effect: > 300 mg/kg
Compound 3: no number, only a limit (the forecaster's own chance of this, stated with the estimate: 65%); middle value at least 1.0-fold (0.02 log units) from the limit.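

Compound 3 gives > 300 mg/kg in this assay, which is a limit of the assay and not a number. No step between compound 1, compound 2 and compound 3 can be read, and all three stop at the same limit: the limit of > 300 mg/kg in this assay, at which 3 of the 3 values shown sit.

Going by these compounds, whether 2-methoxyphenyl, 3,4-dimethoxyphenyl and 4-bromophenyl differ at all in the dose they need stays open.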